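Amide substituent variation on the shared core

The compounds below may be only part of what the source reports. "The series", "measured", "known", "first", "only" and "open" are said of these compounds alone.

Compound 1 `Nc1nn(CC(=O)NCCO)c2nc(-c3ccccc3)cc(C(F)(F)F)c12` and compound 2 `Nc1nn(CC(=O)N2CCOCC2)c2nc(-c3ccccc3)cc(C(F)(F)F)c12` have the same core and differ only in the group on the carbonyl carbon. Among the measured compounds shown here, in a functional assay on HeLa cells (Homo sapiens) for cytotoxicity, read by MTT assay, with a stated time of 24 h (a higher number here means a weaker inhibitor, a lower number a stronger inhibitor), compound 1 gives 69500 nM, the higher of the two numbers measured so far; compound 2 gives 6600 nM. For the measured compounds named here, the single measured step, an 11-fold lower number from compound 1 to compound 2 (1.02 log units; beyond the scatter), puts morpholin-4-yl in place of (2-hydroxyethyl)amino on the carbonyl carbon. Compound 3 `CC(NC(=O)Cn1nc(N)c2c(C(F)(F)F)cc(-c3ccccc3)nc21)C(=O)O` instead keeps the amide-type nitrogen of compound 1 and alters its substituent: 1-carboxyethyl in place of 2-hydroxyethyl on an amide-type nitrogen. Going by the values given here, no measured step covers this exchange; the step from compound 1 to compound 2 concerns a different replacement and gives no direct reading for the 1-carboxyethyl group. For compound 3 in this assay a step of a 1.2-fold higher number from compound 1 to compound 3 (0.09 log units; within the scatter) is expected, within the scatter or slightly toward a higher number, with an estimate of 85000 nM and a range from 25000 nM to 250000 nM.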

Compound 3, half-maximal inhibitory concentration: 20100 nM
Compound 3: the middle estimate sits 4.2-fold (0.63 log units) above what was measured; measured number outside the range, below it.
By their numbers in this assay, from the lowest: compound 2; then compound 3; then compound 1.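

In this assay the amide-type nitrogen of compound 1 can be kept and the number still moves: 1-carboxyethyl in place of 2-hydroxyethyl gives a 3.5-fold lower number from compound 1 to compound 3 (0.54 log units; beyond the scatter) and this exchange on the nitrogen is a change beyond the scatter, so the morpholin-4-yl replacement is no longer the only one shown to lower the number. The retained amide-type nitrogen does not reach the level of the morpholin-4-yl amide, as (1-carboxyethyl)amino in place of morpholin-4-yl on the carbonyl carbon gives a 3.0-fold higher number from compound 2 to compound 3 (0.48 log units; beyond the scatter) and leaves compound 2 with the lowest number of the three. No supporting measurement accounts for either step.

Which part of the 1-carboxyethyl group carries the step remains open, and a methyl ester or a primary amide in place of the carboxylic acid would bear on that. From the compounds shown here alone, how a piperazine on the carbonyl carbon compares with morpholin-4-yl also remains open.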